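Adding a Methyl to Compound 3

The compounds below may be only part of what the source reports. "The series", "measured", "known", "first", "only" and "open" are said of these compounds alone.

In an ADME assay on microsomes from liver (Mus musculus) for metabolic stability, read by LC-MS, with a stated time of 30 min, tested at 1 uM (a lower number here means that less of the compound is left, a higher number that more of the compound is left), compound 3 `CC(=O)N1CCN(C(=O)[C@@H]2CC[C@@H](C)N2C(=O)C2=C(C(C)C)N3C(=N[C@@](C)(c4ccc(Cl)cc4)[C@H]3c3ccc(Cl)cc3)S2)C[C@H]1C` gives 55%, level within the scatter with compound 1 `CC[C@@H]1CC[C@@H](C(=O)N2CCN(C)CC2)N1C(=O)C1=C(C(C)C)N2C(=N[C@@](C)(c3ccc(Cl)cc3)[C@H]2c2ccc(Cl)cc2)S1` at 50%. Compound 2 `CC[C@@H]1CC[C@@H](C(=O)N2CCN(C(C)=O)CC2)N1C(=O)C1=C(C(C)C)N2C(=N[C@@](C)(c3ccc(Cl)cc3)[C@H]2c2ccc(Cl)cc2)S1` gives 38%, clearly lower than both. Compound 4 `CC[C@@H]1CC[C@@H](C(=O)N2CCN(C(C)=O)[C@H](C)C2)N1C(=O)C1=C(C(C)C)N2C(=N[C@@](C)(c3ccc(Cl)cc3)[C@H]2c2ccc(Cl)cc2)S1` differs from compound 3 by methyl in place of hydrogen on a saturated chain carbon bound to a saturated ring carbon, so a methyl becomes an ethyl. Within the data shown here, no measured step covers this change directly. Among the measured compounds shown here, the only guide is a number 12 percentage points lower from compound 1 to compound 2 (beyond the scatter), acetyl in place of methyl on an amine nitrogen in a ring, which lies at another place. Compound 2, which also carries the ethyl, stands at 38%, so a small downward step in this assay is expected. The expected step is a number 10 percentage points lower from compound 3 to compound 4 (within the scatter). Compound 4 is estimated at 45%, within a range from 31% to 59%.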

Compound 4, percent of the compound remaining: 59%
Compound 4: middle estimate off by 14 percentage points, on the low side; the range from low to high includes it.
By their numbers in this assay, from the lowest: compound 2; then compounds 1, 3 and 4 (each within the scatter of the next).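

In this assay, methyl in place of hydrogen on a saturated chain carbon bound to a saturated ring carbon, which turns methyl into ethyl, gives a number 4 percentage points higher from compound 3 to compound 4 (within the scatter) and so shows no real change at this position. Methyl in place of hydrogen on a saturated ring carbon, a different place, gives a number 21 percentage points higher from compound 2 to compound 4 (beyond the scatter) and is a clearer change. The larger group on the carbonyl carbon gives a number 9 percentage points higher from compound 1 to compound 4 (within the scatter) and likewise shows no real change.

No evidence is available to explain these steps. As far as these compounds go, whether a propyl group or a longer chain at the ethyl position would match the ethyl remains open.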